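The source may hold more compounds than are shown below. What is called first, only, known or untested is meant among the compounds shown, and "the series" means these compounds.

The three measured compounds share one core, seen in compound 1 as `CC(C)(C)OC(=O)N1CCC(O[C@H]2CC[C@H](Oc3cnc(S(C)(=O)=O)cn3)CC2)CC1`, and differ only in the group carried on the ring nitrogen of the six-membered non-aromatic ring. In a functional assay on isolated protein for agonist activity at Glucose-dependent insulinotropic receptor (Rattus norvegicus), read by HTRF and cAMP accumulation (a higher number here means that more compound is needed for the effect, a lower number that less compound is needed), compound 1 gives 64 nM. Compound 2, `CC1(OC(=O)N2CCC(O[C@H]3CC[C@H](Oc4cnc(S(C)(=O)=O)cn4)CC3)CC2)CC1`, gives 138 nM in this assay, and compound 3, `CS(=O)(=O)c1cnc(O[C@H]2CC[C@H](OC3CCN(C(=O)Oc4ccccc4)CC3)CC2)cn1`, gives 71.8 nM. Compound 3 stands second highest of the three numbers; the two steps that end at it are a 1.1-fold higher number from compound 1 to compound 3 (0.05 log units; within the scatter) and a 1.9-fold lower number from compound 2 to compound 3 (0.28 log units; within the scatter), both within the scatter. Within the data shown here, the only step beyond the scatter in the set is a 2.2-fold higher number from compound 1 to compound 2 (0.33 log units; beyond the scatter).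

Compound 4, `CS(=O)(=O)c1cnc(O[C@H]2CC[C@H](OC3CCN(CC4(C(F)(F)F)CCCC4)CC3)CC2)cn1`, is the next compound to be measured. Against compound 3 the change is a group of 10 heavy atoms (7 carbon, 3 fluorine; one five-membered non-aromatic ring of carbon only) in place of a group of 9 heavy atoms (7 carbon, 2 oxygen; one six-membered aromatic ring of carbon only), on an amine nitrogen in a ring. Among the measured compounds shown here, every measured step so far exchanged only the group on an oxygen next to a carbonyl group and kept that carbonyl; the largest of them, a 2.2-fold higher number from compound 1 to compound 2 (0.33 log units; beyond the scatter), was modest. For the measured compounds named here, the step to compound 4 removes the carbonyl and both oxygens altogether, and no measured pair bears on that directly. The step is therefore expected to be a 2.1-fold higher number from compound 3 to compound 4 (0.32 log units; beyond the scatter), read with a wide range. Compound 4 is estimated at 150 nM in this assay, between 40 nM and 600 nM.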

Compound 4, half-maximal effective concentration: 101 nM
The estimate for compound 4 lay 1.5-fold (0.17 log units) above the measured number; the range from low to high includes it.
By their numbers in this assay, from the lowest: compounds 1, 3, 4 and 2 (each within the scatter of the next, the first and the last beyond it).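

Among these compounds, on an amine nitrogen in a ring, the earlier compounds varied only the group on the oxygen and kept the carbonyl, whereas compound 4 shows that in this assay the whole phenoxycarbonyl group can give way to a group of 10 heavy atoms, with one five-membered non-aromatic ring of carbon only and 0 hydrogen-bond acceptors, with a step that stays within the scatter: a 1.4-fold higher number from compound 3 to compound 4 (0.15 log units; within the scatter). The same reading holds against the other two compounds, with a 1.4-fold lower number from compound 2 to compound 4 (0.14 log units; within the scatter) and a 1.6-fold higher number from compound 1 to compound 4 (0.20 log units; within the scatter), so among these four compounds the carbonyl and its two oxygens are not needed for a number in this range. Nothing measured on these compounds speaks to why the number holds across so large an exchange.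

The compounds shown do not separate the trifluoromethyl from the five-membered ring, so the contribution of each within the entering group remains unknown. Also open, from the compounds shown here alone, is how this nitrogen would read with a plain cyclopentylmethyl group, an amide carbonyl or a carboxylic acid on the substituent, and whether the flat response holds for any of them.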